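The compounds below may be only part of what the source reports. "The series", "measured", "known", "first", "only" and "open" are said of these compounds alone.

In a functional assay on Gurav cells (Homo sapiens) for inhibition, read by sulforhodamine B assay (a lower number here means a stronger inhibitor of growth, a higher number a weaker inhibitor of growth), compound 3 (`Fc1ccc(-c2ccc(-c3ccc(-c4nc5ccccc5[nH]4)cc3)cc2)cc1`) stands at 100000 nM, the weakest of the three measured compounds. Compound 1 (`Cc1ccc2[nH]c(-c3ccc(-c4ccc(-c5ccc(N(C)C)cc5)cc4)cc3)nc2c1`) gives 6240 nM, and compound 2 (`COc1ccc(-c2ccc(-c3ccc(-c4nc5cc(C)ccc5[nH]4)cc3)cc2)cc1OC`) gives 1310 nM.

The next compound is compound 4 (`Oc1ccc(-c2ccc(-c3ccc(-c4nc5ccccc5[nH]4)cc3)cc2)cc1`), with hydroxy in place of fluoro on an aromatic carbon, para to a large group: hydroxy in place of fluoro on an aromatic carbon. Going by the values given here, no measured pair shows this exchange. The closest evidence is a 4.8-fold lower number from compound 1 to compound 2 (0.68 log units; beyond the scatter), where 3,4-dimethoxyphenyl replaces 4-(dimethylamino)phenyl. That step is modest, and the cores of both compounds differ from that of compound 3, so it indicates a plausible size but no direction for the fluoro to hydroxy change.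

Direction rests only on compound 3 holding the highest number in the set at 100000 nM, which leaves a lower value as the more likely outcome in this assay. The expected change is of similar modest size, an estimated 4.0-fold lower number from compound 3 to compound 4 (0.60 log units; beyond the scatter). Compound 4 is estimated at 25000 nM, with an expected range of 5000 nM to 100000 nM.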

Compound 4, concentration for 50% growth inhibition: 100000 nM
Estimate against measurement, compound 4: 4.0-fold (0.60 log units) below, and the stated range covers the measured number.
By their numbers in this assay, from the lowest: compound 2; then compound 1; then compounds 3 and 4 (each within the scatter of the next).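

In this assay, hydroxy in place of fluoro on an aromatic carbon, para to a large group, gives no change at the digits printed from compound 3 to compound 4 (within the scatter). At this place, the hydrogen-bond donor and acceptor that enter with hydroxy leave the read-out unmoved, whereas the earlier exchange of whole end groups gave a 4.8-fold lower number from compound 1 to compound 2 (0.68 log units; beyond the scatter). No accompanying measurement offers an explanation for this flat result.

Compounds 3 and 4 differ from compounds 1 and 2 in more than one place, so the contribution of the core and that of the end group cannot be separated. Going by these compounds, whether a carboxylic acid or a primary amine at this same place would give a different number from 4-fluorophenyl and 4-hydroxyphenyl remains open.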